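A chloro substituent on the phenyl ring of compound 1

A few compounds are considered here, and "the series" means these few. Any claim that something is new, unique, unknown or untested is made for them only; others in the source may bear on it.

Compound 1 `COC(=O)C[C@H](O)C[C@H](O)/C=C/n1c(C(C)C)cc(-c2ccccc2)c1-c1ccc(F)cc1` gives 2 nM in an assay for inhibition of 3-hydroxy-3-methylglutaryl-coenzyme A reductase (Rattus norvegicus), using microsomes (on this read-out lower numbers stand for stronger inhibition and higher numbers for weaker inhibition), the lowest of the two numbers measured. Within the data shown here, compound 2 `COC(=O)C[C@H](O)C[C@H](O)/C=C/n1c(C(C)C)cc(-c2ccc(F)cc2)c1-c1cccc(Br)c1` gives 69 nM in this assay; the two structures differ in more than one place, so no single step links them. Compound 3 `COC(=O)C[C@H](O)C[C@H](O)/C=C/n1c(C(C)C)cc(-c2cccc(Cl)c2)c1-c1ccc(F)cc1` carries chloro in place of hydrogen on an aromatic carbon; the same difference, cut one bond further out, reads phenyl to 3-chlorophenyl. Among the measured compounds shown here, no measured pair isolates this change, so a small step toward weaker inhibition is expected, and the estimated step reads a 3.0-fold higher number from compound 1 to compound 3 (0.48 log units; beyond the scatter). Compound 3 is therefore expected to give 6 nM, within a range from 2 nM to 20 nM.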

Compound 3, half-maximal inhibitory concentration: 2 nM
Beside the measured number, compound 3's estimate is 3.0-fold (0.48 log units) above it; low and high end bracket the measured number.
By their numbers in this assay, from the lowest: compounds 1 and 3 (each within the scatter of the next); then compound 2.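

Chloro in place of hydrogen on this aromatic carbon gives no change at the digits printed from compound 1 to compound 3 (within the scatter) in this assay, so this position of the phenyl ring takes one added chlorine with no change the assay can resolve. Compound 1 and compound 2 could not show this, as they differ in more than one place. No supporting data bear on why the number holds. Open, going by these compounds, is whether a larger or different group at this position, such as an amine, a carboxylic acid or a longer alkyl chain, would also leave the number unchanged.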